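The source may report more compounds than this note shows. Statements on the series, on what has been measured and on what is new or still open speak of the compounds shown alone.

Of the compounds shown here, two sharing the same core have been measured so far. Compound 1 `CCCCn1cc(CO[C@H]2CC(=O)[C@@H]3OC[C@H]2O3)nn1` and compound 2 `O=C1C[C@H](OCc2cc(-c3ccccc3)no2)[C@H]2CO[C@@H]1O2` differ in the group hung from the core through a short linker. In a functional assay on MDA-MB-231 cells (Homo sapiens) for cytotoxicity, read by MTT assay, with a stated time of 48 h (on this read-out higher numbers stand for weaker inhibition and lower numbers for stronger inhibition), compound 1 gives 27900 nM, and compound 2 gives 21900 nM. Of these two numbers, compound 2 carries the lower one, but the gap to compound 1 lies within the scatter, so nothing separates them. Compound 3 `COc1ccc(-c2cc(CO[C@H]3CC(=O)[C@@H]4OC[C@H]3O4)on2)cc1` has not yet been measured. It differs from compound 2 in a single place: methoxy in place of hydrogen on an aromatic carbon. Within the data shown here, no measured pair shows the effect of this change, so there is no step to lean on. The expected step in this assay a 1.5-fold lower number from compound 2 to compound 3 (0.16 log units; within the scatter) is therefore small, with no direction beyond the scatter. Compound 3 is estimated at 15000 nM, with a range from 6000 nM to 40000 nM.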

Compound 3, half-maximal inhibitory concentration: 21900 nM
Compound 3: the middle estimate sits 1.5-fold (0.16 log units) below what was measured; measured number inside the range.
By their numbers in this assay, from the lowest: compounds 2, 3 and 1 (each within the scatter of the next).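

In this assay, among these compounds, compound 3 gives the first reading of a change made in one place, the swap of phenyl to 4-methoxyphenyl, and the result is no change at the digits printed from compound 2 to compound 3 (within the scatter) for this methoxy in place of hydrogen on an aromatic carbon. So at this position, para to a large group, adding methoxy leaves the cytotoxicity number where it was, which the comparison of compound 1 with compound 2 could not show, since those two differ in a whole group. Nothing measured here explains why the number holds steady.

One group at one position says little about the position as a whole. On these data alone, whether an amine, a carboxylic acid or a longer chain such as butoxy on this same ring carbon would move the number beyond the scatter remains open.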